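Chloro in Place of Methyl: Expectation for Compound 3

The source may hold more compounds than are shown below. What is called first, only, known or untested is meant among the compounds shown, and "the series" means these compounds.

Measured compounds:
compound 1, `COc1cc2oc(-c3cccc(NC(=O)c4ccc(C)cc4)c3)cc(=O)c2c(OC)c1OC`: in a functional assay on UACC-257 cells (Homo sapiens) for inhibition, read by sulforhodamine B assay, tested at 10 uM (on this read-out higher numbers stand for more inhibition at the one concentration tested (going by the name of the read-out) and lower numbers for less inhibition), compound 1 gives 56.1%
compound 2, `COc1cc2oc(-c3cccc(C(=O)Nc4ccc(C)cc4)c3)cc(=O)c2c(OC)c1OC`: in this assay compound 2 gives 70.1%

Within the data shown here, compound 2 stands highest of the two numbers measured so far. Among the measured compounds shown here, its nearest neighbour is compound 1, and the single step between them, a number 14 percentage points higher from compound 1 to compound 2 (beyond the scatter), is beyond the scatter and modest in size.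

Compound 3, `COc1cc2oc(-c3cccc(C(=O)Nc4ccc(Cl)cc4)c3)cc(=O)c2c(OC)c1OC`, is the next compound in this series. It differs from compound 2 in one place: chloro in place of methyl on an aromatic carbon. For the measured compounds named here, the only measured step, a number 14 percentage points higher from compound 1 to compound 2 (beyond the scatter), concerns the direction of the amide link and leaves the six-membered aromatic ring of carbon only untouched, so no measured step bears directly on an exchange of methyl for chloro at that ring. With nothing in the data pointing in either direction, the estimated step is a number 2.1 percentage points lower from compound 2 to compound 3 (within the scatter), and the number is expected to stay within the scatter of compound 2. Going by the values given here, on that basis compound 3 is estimated at 68% in this assay, with a range from 50% to 85%, the wide range reflecting that no measured step informs this change.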

Compound 3, a percentage reported as inhibition, at one concentration (the size of the read-out at that concentration, not a potency): 107%
Beside the measured number, compound 3's estimate is 39 percentage points below it; measured number outside the range, above it.
By their numbers in this assay, from the lowest: compound 1; then compound 2; then compound 3.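

Among these compounds, the para substituent on the terminal aromatic ring, previously untested, turns out to matter a great deal in this assay: exchanging methyl for chloro on that aromatic carbon gives a number 36.9 percentage points higher from compound 2 to compound 3 (beyond the scatter) and is classed as large, whereas the only earlier change, the reversal of the amide link, gave a number 14 percentage points higher from compound 1 to compound 2 (beyond the scatter) and was classed as modest. The exchange replaces one heavy atom with one heavy atom and leaves the counts of hydrogen-bond donors, hydrogen-bond acceptors and net charge unchanged, yet the two changes together amount to a number 50.9 percentage points higher from compound 1 to compound 3 (beyond the scatter) with the reversed amide and the chloro group both in place. No measurement in hand accounts for why this single-atom exchange has such an effect.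

Going by these compounds, whether the gain belongs to chloro alone or would also appear with fluoro, bromo, methoxy or trifluoromethyl at this position remains open, as does whether chloro would bring a similar gain in the amide orientation of compound 1. The compounds shown also leave open how an amine or a carboxylic acid at this position would behave.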